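Adding a methoxy group beside the aldehyde of compound 3

This account rests on a few compounds, and the source may have more. Where it says the series, first, only, none or still open, it means among the compounds named here.

Of the compounds shown here, three have been tested in an ADME assay on HEK-293T cells (Homo sapiens) for cytotoxicity, read by MTT assay, with a stated time of 24 h; a lower number here means a stronger inhibitor, a higher number a weaker inhibitor. Compound 1 `C#CCOc1ccc(/C=N/Cc2ccc(S(N)(=O)=O)cc2)cc1` gives 398000 nM, compound 2 `C#CCOc1c(/C=N/Cc2ccc(S(N)(=O)=O)cc2)cccc1OC` gives 135000 nM, and compound 3 `O=Cc1ccccc1OCc1cn(CCCOc2ccc3ccc(=O)oc3c2)nn1` gives 13700 nM, the lowest of the three numbers, clearly apart from both others. Compound 4 `COc1cccc(C=O)c1OCc1cn(CCCOc2ccc3ccc(=O)oc3c2)nn1` differs from compound 3 in one place: methoxy in place of hydrogen on an aromatic carbon, sitting ortho to a large group and meta to the formyl group. Going by the values given here, no measured pair shows what such a change alone does, and compounds 1 and 2 differ in more than this one place, so their two values cannot be read as a step. The expected step from compound 3 to compound 4 in this assay is therefore small, a 1.1-fold lower number from compound 3 to compound 4 (0.02 log units; within the scatter), with no direction beyond the usual scatter. For compound 4 an estimate of 13000 nM is expected, within a range from 4000 nM to 40000 nM.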

Compound 4, half-maximal inhibitory concentration: 30400 nM
For compound 4 the middle estimate is 2.3-fold (0.37 log units) below the measured one, and the stated range covers the measured number.
By their numbers in this assay, from the lowest: compound 3; then compound 4; then compound 2; then compound 1.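

In this assay, methoxy in place of hydrogen on this aromatic carbon gives a 2.2-fold higher number from compound 3 to compound 4 (0.35 log units; beyond the scatter), a modest step but beyond the scatter. Going by these compounds alone, this is the first change in a single place, and it shows that this position, ortho to a large group and meta to the formyl group, does affect the number, with methoxy making the compound a weaker inhibitor. Nothing available explains this step.

Methoxy is the only group shown here, so a hydroxyl group, a fluorine atom or a longer chain such as ethoxy remains open.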